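Methylsulfanyl to nitro on the shared core: working notes

The source may hold more compounds than are shown below. What is called first, only, known or untested is meant among the compounds shown, and "the series" means these compounds.

Measured in a functional assay on Chorioallantoic membrane (Gallus gallus, strain Leghorn), read by microscopy, with a stated time of 40 h; a lower number here means a stronger inhibitor, a higher number a weaker inhibitor:
- compound 1 `COc1ccc(N(c2ncnc3occ(C)c23)C(C)C)cc1`: 480 nM
- compound 2 `CSc1ccc(N(C)c2ncnc3occ(C)c23)cc1`: 520 nM

Compound 2 at 520 nM stands within the usual scatter of compound 1 at 480 nM, so the two numbers give no ranking. Compound 3 `Cc1coc2ncnc(N(C)c3ccc([N+](=O)[O-])cc3)c12` has nitro in place of methylsulfanyl on an aromatic carbon, para to a large group: nitro in place of methylsulfanyl on an aromatic carbon. Within the data shown here, the two measured compounds differ in more than one place, so the series holds no measured single-place step to size this change. Among the measured compounds shown here, the only anchor is compound 2 at 520 nM. A modest move toward weaker inhibition is expected in this assay, about the size of the scatter or slightly beyond it, and this remains a tentative call. The estimated step is a 2.1-fold higher number from compound 2 to compound 3 (0.33 log units; beyond the scatter). For compound 3 the expected value is 1100 nM, with an estimated range of 300 nM to 4000 nM.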

Compound 3, half-maximal inhibitory concentration: 1060 nM
Compound 3: the middle estimate sits 1.0-fold (0.02 log units) above what was measured, and the stated range covers the measured number.
By their numbers in this assay, from the lowest: compounds 1 and 2 (each within the scatter of the next); then compound 3.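

Working from the first single-place step in the series, in this assay nitro in place of methylsulfanyl on an aromatic carbon, para to a large group, gives a 2.0-fold higher number from compound 2 to compound 3 (0.31 log units; beyond the scatter) and so moves modestly toward weaker inhibition. This shows that the number responds to a change at this position, something compound 1 and compound 2 could not show since they differ in more than one place. Nothing measured here accounts for the direction or size of this step.

A single replacement cannot show how other groups at this position, such as an amine, a carboxylic acid or a longer chain, would compare with methylsulfanyl and nitro. The separate contributions of the places in which compound 1 and compound 2 differ also remain unsized.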